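The source may hold more compounds than are shown below. What is called first, only, known or untested is meant among the compounds shown, and "the series" means these compounds.

Working notes on the series.

Compound 1 `O=c1c2cnn(-c3ccc(F)cc3)c2ncn1CC1(O)CCN(Cc2ccccc2Cl)CC1` gives 3400 nM in an assay on Sf21 cells for inhibition of ubiquitin carboxyl-terminal hydrolase 7 (Homo sapiens), read by spectrophotometry, with stated times of 30 min and 2 h; a higher number here means a weaker inhibitor, a lower number a stronger inhibitor. Compound 2 `O=c1c2cnn(-c3ccc(F)cc3)c2ncn1CC1(O)CCN(Cc2ccc(Cl)cc2Cl)CC1` carries a further chloro on the same benzyl ring and gives 3300 nM in this assay; the step of a 1.0-fold lower number from compound 1 to compound 2 (0.01 log units; within the scatter) is within the scatter. Going by the values given here, compound 2 thus has the lowest of the two numbers so far, but its value and that of compound 1 cannot be told apart.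

Compound 3 `N#Cc1cc(Cl)ccc1CN1CCC(O)(Cn2cnc3c(cnn3-c3ccc(F)cc3)c2=O)CC1` is not yet measured. It differs from compound 2 by cyano in place of chloro on an aromatic carbon, on an aromatic carbon of the six-membered ring of carbon only, meta to a chloro group. Among the compounds with values here, no measured step swaps chloro for cyano; the only step in hand, a 1.0-fold lower number from compound 1 to compound 2 (0.01 log units; within the scatter), adds a chloro and shows no shift beyond the scatter. Compound 3 is therefore expected to stay close to compound 2, with an estimated step of no change at the digits printed from compound 2 to compound 3 (within the scatter). The estimate for compound 3 in this assay is 3300 nM, between 1200 nM and 9000 nM.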

Compound 3, half-maximal inhibitory concentration: 11400 nM
Beside the measured number, compound 3's estimate is 3.5-fold (0.54 log units) below it, and the stated range ends below it.
By their numbers in this assay, from the lowest: compounds 2 and 1 (each within the scatter of the next); then compound 3.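

The earlier step changed the benzyl ring without any shift beyond the scatter, but in this assay the ring is not indifferent to every change: on this aromatic carbon, ortho to a large group, cyano in place of chloro gives a 3.5-fold higher number from compound 2 to compound 3 (0.54 log units; beyond the scatter), a modest loss. Measured against the 2-chlorophenyl of compound 1, the 4-chloro-2-cyanophenyl group gives a 3.4-fold higher number from compound 1 to compound 3 (0.53 log units; beyond the scatter), so both routes to compound 3 show a loss of similar size. Nothing measured here explains this loss.

On these data alone, whether it is specific to cyano remains open, as a methyl, a methoxy or an amine at this place could stay with compound 2 or fall with compound 3. Also open, as far as these compounds go, is whether cyano has the same effect on a benzyl ring without the chloro group.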